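The source may hold more compounds than are shown below. What is called first, only, known or untested is meant among the compounds shown, and "the series" means these compounds.

Measured in an ADME assay on MRC5 cells (Homo sapiens), read by MTT assay, with a stated time of 72 h; on this read-out lower numbers stand for stronger inhibition and higher numbers for weaker inhibition:
- Compound 1 `C#Cc1cn([C@@H]2O[C@H](CO)[C@@H](O)[C@H]2O)c2ncnc(OC)c12`: > 100000 nM, a limit
- Compound 2 `Cc1ncnc2c1c(-c1cccs1)cn2[C@@H]1O[C@H](CO)[C@@H](O)[C@H]1O`: > 100000 nM, a limit
- Compound 3 `Cc1ncnc2c1c(-c1ccsc1)cn2[C@@H]1O[C@H](CO)[C@@H](O)[C@H]1O`: > 100000 nM, a limit

Within the data shown here, no compound in this set has a numeric value, and the set as a whole shows (the limit of > 100000 nM in this assay, at which 3 of the 3 values shown sit). Among the measured compounds shown here, the only measured step is a step that the two limits leave unreadable from compound 2 to compound 3, so it gives no size to carry forward.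

Compound 4 `C#Cc1cn([C@@H]2O[C@H](CO)[C@@H](O)[C@H]2O)c2ncnc(C)c12` follows from compound 3 by ethynyl in place of thiophen-3-yl on an aromatic carbon.

Compound 1, which also carries ethynyl, reads > 100000 nM, again a limit. For the measured compounds named here, no sizeable step is therefore expected in this assay, though a modest move toward stronger inhibition cannot be excluded.

The expected change is an at least 1.4-fold lower number from compound 3 to compound 4 (0.15 log units; that floor lies within the scatter). Compound 4 is estimated at 70000 nM, with an expected range of 10000 nM to 100000 nM.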

Compound 4, half-maximal inhibitory concentration: 1440 nM
Compound 4: the middle estimate sits 49-fold (1.69 log units) above what was measured, and the stated range ends above it.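

In this assay, among these compounds, ethynyl in place of thiophen-3-yl gives an at least 69-fold lower number from compound 3 to compound 4 (1.84 log units; beyond the scatter) and ethynyl in place of thiophen-2-yl gives an at least 69-fold lower number from compound 2 to compound 4 (1.84 log units; beyond the scatter) as the first numeric value in the set. Ethynyl alone does not suffice: compound 1 also carries it, and methyl in place of methoxy on an aromatic carbon gives an at least 69-fold lower number from compound 1 to compound 4 (1.84 log units; beyond the scatter) with ethynyl held fixed. Each step is only a floor, as each starting compound sits at a limit: the limit of > 100000 nM in this assay, at which 3 of the 4 values shown sit.

Open, going by these compounds, is whether a propynyl chain, a nitrile or an amine in place of ethynyl keeps this value. Also open, on these data alone, is whether an ethyl group or chlorine can replace the methyl.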